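Methyl on the pyridine of compound 1: cytotoxicity notes

The source may report more compounds than this note shows. Statements on the series, on what has been measured and on what is new or still open speak of the compounds shown alone.

Compound 1 (`Nc1ccccc1NC(=O)c1ccc(NC(=S)NCc2cccnc2)cc1`) offers no starting number: in a functional assay on MDA-MB-231 cells (Homo sapiens) for cytotoxicity, read by MTT assay, with a stated time of 72 h (a higher number here means a weaker inhibitor, a lower number a stronger inhibitor), compound 1 stands as "not determined" (no result reported) and has no single value. Among the compounds with values here, the only measured point is compound 2 (`Nc1ccccc1NC(=O)c1ccc(NC(=O)NCc2ccc(Cl)nc2)cc1`), which gives 34000 nM in this assay and cannot be compared with a value for compound 1.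

Compound 3 (`Cc1ccc(CNC(=S)Nc2ccc(C(=O)Nc3ccccc3N)cc2)cn1`) comes from compound 1 through one change, methyl in place of hydrogen on an aromatic carbon with methyl in place of hydrogen on an aromatic carbon, next to the ring nitrogen and para to a large group. Pyridin-3-yl thus becomes 6-methylpyridin-3-yl.

Within the data shown here, no measured step speaks to this change. In this assay the step from compound 1 to compound 3 is expected to stay within the scatter, with no direction favoured. With no value for compound 1, the estimate leans on compound 2 at 34000 nM as the sole anchor, and the range is kept wide. Compound 3 is expected at 25000 nM with an estimated range from 7000 nM to 80000 nM in this assay as the working figure.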

Compound 3, half-maximal inhibitory concentration: 63000 nM
Beside the measured number, compound 3's estimate is 2.5-fold (0.40 log units) below it; the range from low to high includes it.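

No step can be read for compound 3: compound 1 has no single number in this assay, and compound 2 differs from compound 3 in more than one place. The compounds shown leave open what pyridin-3-yl to 6-methylpyridin-3-yl does to cytotoxicity in this assay. No supporting evidence bears on the result.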